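Replacing (4-methoxyphenyl)amino with dipropylamino in compound 2

The source may hold more compounds than are shown below. What is called first, only, known or untested is meant among the compounds shown, and "the series" means these compounds.

Within the data shown here, in a functional assay on MCF7 cells (Homo sapiens) for inhibition, read by sulforhodamine B assay (a lower number here means a stronger inhibitor, a higher number a weaker inhibitor), compound 2 `COc1ccc(NC2=CC(=O)c3c(nc4n3[C@H]3OC[C@@H](O)[C@H]3OC4)C2=O)cc1` gives 4470 nM, the only actual number available for this small series. Compound 1 `O=C1C(Nc2ccccc2)=CC(=O)c2c1nc1n2[C@H]2OC[C@@H](O)[C@H]2OC1` gives > 4000 nM, which is a limit and not a number. That reading is the limit of > 4000 nM in this assay, at which 1 of the 2 values shown sits.

Among the measured compounds shown here, the one measured step is a step that the limit leaves unreadable from compound 1 to compound 2. It is methoxy in place of hydrogen on an aromatic carbon, and it offers no size to carry forward.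

Compound 3 `CCCN(CCC)C1=CC(=O)c2c(nc3n2[C@H]2OC[C@@H](O)[C@H]2OC3)C1=O` keeps the shared core but changes the whole substituent: dipropylamino in place of (4-methoxyphenyl)amino on a double-bonded ring carbon. In words, this is dipropylamino in place of (4-methoxyphenyl)amino on a double-bonded ring carbon. For the measured compounds named here, no measured step replaces this group, so the data give no direction for the change.

The expectation therefore stays anchored on compound 2 at 4470 nM, with no step beyond the scatter expected in this assay. The estimate amounts to a 1.3-fold lower number from compound 2 to compound 3 (0.11 log units; within the scatter), an expected change without a firm direction. For compound 3 the estimated value is 3500 nM, with an expected range of 1000 nM to 12000 nM.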

Compound 3, half-maximal inhibitory concentration: > 16000 nM
Compound 3: only a limit was reported (the forecaster's own chance of this, stated with the estimate: 35%); middle value at least 4.5-fold (0.66 log units) away from the limit.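

In this assay compound 3 gives > 16000 nM, which is a limit and not a number. Among these compounds, putting dipropylamino in place of (4-methoxyphenyl)amino is an at least 3.5-fold higher number from compound 2 to compound 3 (0.55 log units; beyond the scatter), the only readable step in this small series, and it shows that the substituent on this double-bonded ring carbon can move the reading, here towards weaker inhibition. The change is a whole-group exchange, though: the six-membered aromatic ring and the hydrogen-bond donor leave together, and two propyl chains enter on the nitrogen, so this single step cannot separate these differences.

The steps from compound 1 to compound 2 and from compound 1 to compound 3 cannot be read, which leaves the effect of the methoxy group and the standing of the unsubstituted anilino group unresolved. Also open, going by these compounds, is whether a group that changes only one of these features, such as propylamino with its single chain or a cyclohexylamino group without an aromatic ring, would read closer to compound 2 or to compound 3.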